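Swapping a Phenyl for a Methyl on the Carbonyl

The compounds below may be only part of what the source reports. "The series", "measured", "known", "first", "only" and "open" are said of these compounds alone.

Of the compounds shown here, three built on a shared core have been tested in a functional assay on PC-3 cells (Homo sapiens) for inhibition, read by sulforhodamine B assay, with a stated time of 48 h; on this read-out higher numbers stand for weaker inhibition of growth and lower numbers for stronger inhibition of growth. Compound 1 `N#C/C(=C\c1c(-c2ccccc2)[nH]c2ccccc12)C(=O)c1ccccc1` gives 3500 nM, compound 2 `CCOC(=O)C(=Cc1c(-c2ccccc2)[nH]c2ccccc12)C(=O)OCC` gives 3300 nM, and compound 3 `O=C(/C(=C\c1c(-c2ccccc2)[nH]c2ccccc12)S(=O)(=O)c1ccccc1)c1ccccc1` gives 5000 nM. Compound 3 carries the highest of the three numbers, yet its gaps to compound 1 and to compound 2 both lie within the usual scatter, so the three cannot be told apart in this assay. Compound 4 `CC(=O)/C(=C\c1c(-c2ccccc2)[nH]c2ccccc12)S(=O)(=O)c1ccccc1` differs from compound 3 in one place: methyl in place of phenyl on a carbonyl carbon. Within the data shown here, no measured pair shows this same change, so the data give no guide to its size. The expected step in this assay is a 1.2-fold higher number from compound 3 to compound 4 (0.08 log units; within the scatter), a slight move towards weaker inhibition, not beyond the scatter. Compound 4 is therefore expected to give 6000 nM, between 2500 nM and 15000 nM.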

Compound 4, concentration for 50% growth inhibition: 2500 nM
The estimate for compound 4 lay 2.4-fold (0.38 log units) above the measured number; the measured number falls inside the stated range.
By their numbers in this assay, from the lowest: compounds 4, 2, 1 and 3 (each within the scatter of the next).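

Replacing benzoyl with acetyl on this carbonyl gives a 2.0-fold lower number from compound 3 to compound 4 (0.30 log units; within the scatter) in this assay. The phenyl at this position, with its six-membered aromatic ring, can therefore give way to a single methyl without a change that rises above the scatter, so compound 3 and compound 4 cannot be told apart. No available evidence bears on this result.

The compounds shown leave open how a longer chain or an amine on this carbonyl would read. They also leave open whether the same swap would read alike on compound 1, which also carries benzoyl.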